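Sulfo in place of carboxy on the shared core

The compounds below may be only part of what the source reports. "The series", "measured", "known", "first", "only" and "open" are said of these compounds alone.

The series is read in a functional assay for binding affinity to Macrophage scavenger receptor types I and II (Mus musculus), tested at 100 uM; on this read-out higher numbers stand for more inhibition at the one concentration tested (going by the name of the read-out) and lower numbers for less inhibition. Compound 1 `CCCCCCCCCCCCCCCCCC(=O)Nc1ccc(C(=O)O)c(NC(=O)CCCCCCCCCCCCCCCCC)c1` is the measured parent of the step followed here. In this assay compound 1 returns only the limit of the read-out, < 10%, and no number. Compound 2 `CCCCCCCCCCCCCCCCCC(=O)Nc1ccc(S(=O)(=O)O)cc1` is the other measured member. In this assay compound 2 likewise sits at the limit, < 10%, so no number is known for it either. Going by the values given here, both values shown thus rest on (the limit of < 10% in this assay, at which 2 of the 2 values shown sit), which leaves no measured step and no ordering among the compounds at hand. Compound 3 `CCCCCCCCCCCCCCCCCC(=O)Nc1ccc(S(=O)(=O)O)c(NC(=O)CCCCCCCCCCCCCCCCC)c1` is the unmeasured member; it differs from compound 1 by sulfo in place of carboxy on an aromatic carbon. With both measured compounds at the limit, the step from compound 1 to compound 3 is expected to be none beyond the scatter, a step that the limit leaves unreadable from compound 1 to compound 3. In this assay compound 3 is estimated at 5%, within 0% to 15%, and most likely reported again only as a limit.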

Compound 3, a percentage reported as inhibition, at one concentration (the size of the read-out at that concentration, not a potency): 84.6%
Compound 3: middle estimate off by 79.6 percentage points, on the low side; the whole stated range lies below it.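

Sulfo in place of carboxy on this aromatic carbon, ortho to a large group and para to a large group, gives in this assay the first readable signal of the series: a number at least 74.6 percentage points higher from compound 1 to compound 3 (beyond the scatter). Compound 2 also carries sulfo but lacks the second long amide chain, and its < 10% is a limit of the read-out. Among these compounds, sulfo alone therefore does not bring a reading off the limit, and the size of the step remains a bound rather than a number: the limit of < 10% in this assay, at which 2 of the 3 values shown sit.

On these data alone, whether a phosphono group or a tetrazole on the same carbon would read like sulfo or like carboxy remains open, as does whether shorter chains on both amides would keep the reading of compound 3. A reading at one concentration in this assay also gives no potency for compound 3.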